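Compound 4: swapping the side group for dimethylcarbamoyl

The source may hold more compounds than are shown below. What is called first, only, known or untested is meant among the compounds shown, and "the series" means these compounds.

Values in a functional assay on A549 cells (Homo sapiens) for antiproliferative activity, read by MTT assay, with a stated time of 48 h; a higher number here means a weaker inhibitor, a lower number a stronger inhibitor:
- compound 1 `CC(C)=CCC[C@]1(C)/C=C/[C@@H](OC(=O)C=C(C)C)[C@](C)(O)/C=C/C(=O)/C(CN(C)C)=C\C1`: 590 nM
- compound 2 `CCN(CC)C/C1=C/C[C@](C)(CCC=C(C)C)/C=C/[C@@H](OC(=O)C=C(C)C)[C@](C)(O)/C=C/C1=O`: 130 nM
- compound 3 `COCOC/C1=C/C[C@](C)(CCC=C(C)C)/C=C/[C@@H](OC(=O)C=C(C)C)[C@](C)(O)/C=C/C1=O`: 2980 nM

Compound 3 has the highest number of the three, and its gaps to the other two lie beyond the scatter. Compound 4 `CC(C)=CCC[C@]1(C)/C=C/[C@@H](OC(=O)C=C(C)C)[C@](C)(O)/C=C/C(=O)/C(C(=O)N(C)C)=C\C1` has dimethylcarbamoyl in place of (methoxymethoxy)methyl on a double-bonded ring carbon.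

All three measured steps exchange the group on the same saturated chain carbon. The amine swap gives a 4.5-fold lower number from compound 1 to compound 2 (0.66 log units; beyond the scatter), which is modest. The ether swaps give a 5.1-fold higher number from compound 1 to compound 3 (0.70 log units; beyond the scatter), also modest, and a 23-fold higher number from compound 2 to compound 3 (1.36 log units; beyond the scatter), which is large. None of these steps involves a dimethylcarbamoyl group, so they show how far this region can move the number but not which way this change will go.

Compound 4 carries neither amino group, which points to a result close to compound 3 at 2980 nM. Among the measured compounds shown here, the lower numbers so far belong only to the two amines, compound 1 and compound 2. In this assay, a small drop that stays within the scatter is therefore expected, and a modest move in either direction remains possible. The expected change is a 1.5-fold lower number from compound 3 to compound 4 (0.17 log units; within the scatter). For compound 4 the estimated value is 2000 nM, with an expected range of 500 nM to 8000 nM.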

Compound 4, half-maximal inhibitory concentration: 2700 nM
The estimate for compound 4 lay 1.4-fold (0.13 log units) below the measured number; the measured number falls inside the stated range.
By their numbers in this assay, from the lowest: compound 2; then compound 1; then compounds 4 and 3 (each within the scatter of the next).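

In this assay, dimethylcarbamoyl in place of (methoxymethoxy)methyl on the double-bonded ring carbon gives a 1.1-fold lower number from compound 3 to compound 4 (0.04 log units; within the scatter) and so leaves these two groups indistinguishable at this position, even though one carries a nitrogen and the other does not. Set against the amine-bearing groups, the same dimethylcarbamoyl gives a 4.6-fold higher number from compound 1 to compound 4 (0.66 log units; beyond the scatter) and a 21-fold higher number from compound 2 to compound 4 (1.32 log units; beyond the scatter) as well, which shows that a nitrogen within the group is not enough for the lower numbers: among the four compounds, these belong only to compound 1 and compound 2, where the nitrogen is an amine held on a saturated chain carbon. No measurement available here bears on the reason for this difference between the amine-bearing groups and the other two.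

Still open, as far as these compounds go, is whether the gain seen in going from dimethylamino to diethylamino continues with a cyclic amine such as pyrrolidine or piperidine, or with a longer chain between the ring carbon and the amine. Also open, from the compounds shown here alone, is whether a carboxylic acid or a primary amide at this ring carbon would sit with compound 3 and compound 4 or with the amines.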